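This account rests on a few compounds, and the source may have more. Where it says the series, first, only, none or still open, it means among the compounds named here.

Working notes on the series, all read in a functional assay on A549 cells (Homo sapiens) for inhibition, read by CCK-8 assay, with a stated time of 72 h, tested at 2 uM; a higher number here means more inhibition of growth at the concentration tested, a lower number less inhibition of growth. Compound 1 (`COc1ccc(SCc2ccc(/C=C/C(=O)Nc3ccccc3N)cc2)cc1OC`) gives 65.5%, compound 2 (`Cc1ccc(SCc2ccc(/C=C/C(=O)Nc3ccccc3N)cc2)cc1`) gives 43.4% and compound 3 (`Cc1ccc(SCc2ccc(C(=O)Nc3ccccc3N)cc2)cc1`) gives 40.5%. Compound 3 thus lies within the scatter of compound 2 and beneath compound 1 by a gap beyond the scatter. Compound 4 (`Nc1ccccc1NC(=O)c1ccc(CSc2ccc(Cl)cc2)cc1`) carries one change from compound 3: chloro in place of methyl on an aromatic carbon. The change sits para to a large group and turns 4-methylphenyl into 4-chlorophenyl. Within the data shown here, the only measured step at this end of the molecule is a number 22.1 percentage points lower from compound 1 to compound 2 (beyond the scatter), which is modest. That step exchanges 3,4-dimethoxyphenyl for 4-methylphenyl on the sulfur, a different swap from the present one, so it bears only loosely here. Among the measured compounds shown here, no measured step tests chloro directly, so no shift beyond the scatter is expected. The expected change is a number 1.5 percentage points higher from compound 3 to compound 4 (within the scatter). Compound 4 is estimated at 42%, with an expected range of 28% to 56%.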

Compound 4, percent growth inhibition at one concentration: 47.3%
For compound 4 the middle estimate is 5.3 percentage points below the measured one, and the stated range covers the measured number.
By their numbers in this assay, from the lowest: compounds 3, 2 and 4 (each within the scatter of the next); then compound 1.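

In this assay, among these compounds, chloro in place of methyl on the aromatic carbon gives a number 6.8 percentage points higher from compound 3 to compound 4 (within the scatter) and is the first direct reading of a swap at this carbon. The 4-chlorophenyl and 4-methylphenyl groups on the sulfur therefore cannot be told apart here, on the core of compound 3. Among the compounds shown here, the only earlier step at this end of the molecule, a number 22.1 percentage points lower from compound 1 to compound 2 (beyond the scatter), exchanged a whole substitution pattern, whereas this one exchanges a single group for another of one heavy atom.

Going by these compounds, it remains open how an amine or a carboxylic acid would read on this same carbon. On these data alone, it is also open whether chloro in place of methyl reads the same on the core of compound 2. No measurement at hand bears on what lies behind this result.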